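Swapping a Methylfuran for a Benzofuran

The compounds below may be only part of what the source reports. "The series", "measured", "known", "first", "only" and "open" are said of these compounds alone.

Three measured compounds share a core and differ in one group, on a double-bonded chain carbon bound to an aromatic carbon. In a functional assay on NCI-H460 cells (Homo sapiens) for cytotoxicity, read by MTT assay, with a stated time of 72 h (a higher number here means a weaker inhibitor, a lower number a stronger inhibitor), compound 1 (`CC(C)c1[nH]cnc1/C=c1\[nH]c(=O)/c(=C/c2cccc(Oc3ccc(F)cc3)c2)[nH]c1=O`), carrying 5-isopropyl-1H-imidazol-4-yl, gives 8.8 nM as its result. Compound 3 (`Cc1ccc(/C=c2\[nH]c(=O)/c(=C/c3cccc(Oc4ccc(F)cc4)c3)[nH]c2=O)o1`), carrying 5-methylfuran-2-yl, gives 30 nM and so holds the higher of the two exact numbers. The gap is a modest one, a 3.4-fold higher number from compound 1 to compound 3 (0.53 log units; beyond the scatter) in all. Compound 2 (`O=c1[nH]/c(=C\C2CCCCC2)c(=O)[nH]/c1=C\c1cccc(Oc2ccc(F)cc2)c1`), carrying cyclohexyl, reads > 1000 nM and this is a limit of the assay, not a number. That group marks a large change, an at least 110-fold higher number from compound 1 to compound 2 (2.05 log units; beyond the scatter) in this assay, and the furan recovers most of it, an at least 33-fold lower number from compound 2 to compound 3 (1.52 log units; beyond the scatter) here.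

Compound 4 (`O=c1[nH]/c(=C\c2cc3ccccc3o2)c(=O)[nH]/c1=C\c1cccc(Oc2ccc(F)cc2)c1`) has not been measured. Its change is 1-benzofuran-2-yl in place of 5-methylfuran-2-yl on a double-bonded chain carbon bound to an aromatic carbon and keeps the five-membered aromatic ring while adding a six-membered aromatic ring of carbon only. Within the data shown here, no measured step tests that added ring directly. The closest guide is compound 3, whose a 3.4-fold higher number from compound 1 to compound 3 (0.53 log units; beyond the scatter) was modest, so a modest rise seems likelier than a collapse like an at least 110-fold higher number from compound 1 to compound 2 (2.05 log units; beyond the scatter) in size. The expected change is a 2.3-fold higher number from compound 3 to compound 4 (0.37 log units; beyond the scatter) in this assay on this reasoning. For compound 4 the estimated value is 70 nM with an expected range from 15 nM to 350 nM in the same test.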

Compound 4, half-maximal inhibitory concentration: 347 nM
Estimate against measurement, compound 4: 5.0-fold (0.70 log units) below, and the stated range covers the measured number.
By their numbers in this assay, from the lowest: compound 1; then compound 3; then compound 4. At a limit, above all of these: compound 2.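

In this assay, the added six-membered aromatic ring of carbon only proves to be no small change at this position: a 12-fold higher number from compound 3 to compound 4 (1.06 log units; beyond the scatter). Keeping the five-membered aromatic ring with its oxygen is therefore not enough to keep the result, and the two furan-type groups do not behave alike here, as the gap to the imidazole group grows from the modest 3.4-fold higher number from compound 1 to compound 3 (0.53 log units; beyond the scatter) to a 39-fold higher number from compound 1 to compound 4 (1.60 log units; beyond the scatter). From the compounds shown here alone, the cyclohexyl group still gives the poorest reading, with an at least 2.8-fold lower number from compound 2 to compound 4 (0.45 log units; beyond the scatter), though that step rests on a limit of the assay and not on a number, so its true size stays unknown.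

Nothing measured here says why the larger group gives so much weaker a result. This change also removes a methyl group while it adds a ring, so the open question is which of the two matters more, and a plain furan-2-yl or a phenyl group on the same double-bonded chain carbon would help to pull those two effects apart.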